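The compounds below may be only part of what the source reports. "The series", "measured", "known", "first", "only" and "open" are said of these compounds alone.

Measured compounds:
- compound 1 `CC(C)COc1ccc2c(Cl)ccnc2c1` — 3030 nM
- compound 2 `CCOc1ccc2c(NCCN(C)C)ccnc2c1` — 2520 nM
- compound 3 `CCOc1ccc2c(NCCCN(C)C)ccnc2c1` — 9810 nM

In a functional assay on BGC-823 cells (Homo sapiens) for cytotoxicity, read by MTT assay, with a stated time of 48 h (a lower number here means a stronger inhibitor, a higher number a weaker inhibitor), compound 1 stands second highest of the three numbers; compound 2 sits within the scatter of it, while compound 3 lies beyond the scatter. Compound 4 `C=CCOc1ccc2c(Cl)ccnc2c1` differs from compound 1 by vinyl in place of isopropyl on a saturated chain carbon bound to an oxygen on an aromatic ring. Among the compounds with values here, the only measured step, a 3.9-fold higher number from compound 2 to compound 3 (0.59 log units; beyond the scatter), concerns the amine side chain of two ethoxy compounds and says nothing about the alkoxy group altered here, so it does not bear on the step. Within the data shown here, with no measured precedent for isobutoxy to allyloxy, the expected step of a 1.0-fold lower number from compound 1 to compound 4 (0.00 log units; within the scatter) is none beyond the scatter, and the range is kept wide. Compound 4 is estimated at 3000 nM (1000 nM to 9000 nM).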

Compound 4, half-maximal inhibitory concentration: 2930 nM
Compound 4: middle estimate off by 1.0-fold (0.01 log units), on the high side; measured number inside the range.
By their numbers in this assay, from the lowest: compounds 2, 4 and 1 (each within the scatter of the next); then compound 3.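

In this assay, the first step read at the alkoxy group, isobutoxy to allyloxy, gives a change within the scatter (a 1.0-fold lower number from compound 1 to compound 4 (0.01 log units; within the scatter)). At this place on the shared core, vinyl can therefore stand in for isopropyl with no measurable shift in the number, despite the added double bond and one fewer heavy atom. Nothing measured here offers an explanation for this flat step.

Going by these compounds, it remains open whether a longer chain, an amine or a carboxylic acid at this place would shift the number. On these data alone, it is also open whether the flat step would hold with the dimethylaminoethylamino side chain of compound 2.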